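Compound 2 to compound 3: hydrogen in place of hydroxy

The source may report more compounds than this note shows. Statements on the series, on what has been measured and on what is new or still open speak of the compounds shown alone.

Going by the values given here, in a functional assay on OVCAR cells (Homo sapiens) for cytotoxicity, read by sulforhodamine B assay, with a stated time of 48 h (on this read-out lower numbers stand for stronger inhibition and higher numbers for weaker inhibition), compound 1 `O=CCN1N=C(c2ccc3ccccc3c2)CC1c1cccc(Cl)c1Cl` gives 15100 nM and compound 2 `COc1ccc(C2CC(c3ccc4ccccc4c3)=NN2CC=O)cc1O` gives 2160 nM, the lower of the two numbers so far. Compound 3 `COc1ccc(C2CC(c3ccc4ccccc4c3)=NN2CC=O)cc1` has hydrogen in place of hydroxy on an aromatic carbon, 3-hydroxy-4-methoxyphenyl to 4-methoxyphenyl: hydrogen in place of hydroxy on an aromatic carbon. Among the compounds with values here, the only measured step bearing on this is a 7.0-fold lower number from compound 1 to compound 2 (0.84 log units; beyond the scatter). That step exchanged 2,3-dichlorophenyl as a whole, so the hydroxy is not isolated in the data. The expected step is modest and upward: a 2.1-fold higher number from compound 2 to compound 3 (0.32 log units; beyond the scatter). Compound 3 is estimated at 4500 nM, with an expected range of 1500 nM to 13000 nM.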

Compound 3, half-maximal inhibitory concentration: 5790 nM
Beside the measured number, compound 3's estimate is 1.3-fold (0.11 log units) below it, and the stated range covers the measured number.
By their numbers in this assay, from the lowest: compound 2; then compound 3; then compound 1.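

In this assay, the hydroxy on the aromatic carbon is now isolated: its loss gives a 2.7-fold higher number from compound 2 to compound 3 (0.43 log units; beyond the scatter), so it accounts for part of the earlier gain. The 4-methoxyphenyl without that hydroxy still gives a 2.6-fold lower number from compound 1 to compound 3 (0.42 log units; beyond the scatter), so the gain over 2,3-dichlorophenyl does not rest on the hydroxy alone. Nothing on hand explains either step.

Open, on these data alone, is whether an amino group or a fluorine on that aromatic carbon would match the hydroxy, and whether the hydroxy step carries over to other groups on the core.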